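Shrinking a ring on a pyrazolol growth inhibitor

This account rests on a few compounds, and the source may have more. Where it says the series, first, only, none or still open, it means among the compounds named here.

Measured compounds:
- compound 1, `CS(=O)(=O)c1ccc(-n2nc(-c3ccccc3)cc2O)nc1`, in an ADME assay on WI-38 cells (Homo sapiens) for inhibition, read by CellTiter-Glo, with a stated time of 4 days; a lower number here means a stronger inhibitor of growth, a higher number a weaker inhibitor of growth: > 30000 nM
- compound 2, `Oc1cc(-c2ccccc2)nn1-c1ccc(C(F)(F)F)cn1`: 9400 nM
- compound 3, `Oc1cc(C2CCCCC2)nn1-c1ccccn1`: 9100 nM

The value of compound 1 in this assay is a limit of the assay, not a number; it sits at the limit of > 30000 nM in this assay, at which 1 of the 3 values shown sits. Among the remaining two numbers, compound 3 holds the lower one, but compound 2 stands within the scatter of it, so no order between them can be claimed. Among the measured compounds shown here, the one step that is known, an at least 3.1-fold lower number from compound 1 to compound 2 (0.50 log units; beyond the scatter), concerns the group on the pyridine ring, not the group on the shared core.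

Compound 4, `Oc1cc(C2CCC2)nn1-c1ccccn1`, differs from compound 3 by a single change: cyclobutyl in place of cyclohexyl on an aromatic carbon. For the measured compounds named here, no measured step touches this position, so there is nothing to tell the direction or size of the change in this assay; the one known step lies elsewhere on the molecule and gives no guidance here. The expectation therefore rests on compound 3 alone, with wide uncertainty, and a step of about a 1.6-fold higher number from compound 3 to compound 4 (0.22 log units; within the scatter) is expected. Compound 4 is estimated to give 15000 nM in this assay, with a likely range from 5000 nM to 40000 nM.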

Compound 4, concentration for 50% growth inhibition: 25000 nM
Estimate against measurement, compound 4: 1.7-fold (0.22 log units) below, within the range that was stated.
By their numbers in this assay, from the lowest: compounds 3 and 2 (each within the scatter of the next); then compound 4. At a limit, above all of these: compound 1.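

This position on the shared core now has its first measured step: in this assay, the change gives a 2.7-fold higher number from compound 3 to compound 4 (0.44 log units; beyond the scatter). The size of the carbon ring here therefore matters, and of this pair, the compound with cyclobutyl is the weaker inhibitor of growth, although two ring sizes are too few to establish a trend. Compound 4 still gives a number rather than a limit, but little room remains before further weakening at this position could no longer be put as a number in this assay: the limit of > 30000 nM in this assay, at which 1 of the 4 values shown sits.

The compounds shown leave open whether cyclopentyl, with a ring size between these two, would also give a number between theirs, and whether an open chain such as tert-butyl would behave like either ring. They also leave open whether the same step would appear with trifluoromethyl on the pyridine ring, as both members of this pair carry a plain pyridin-2-yl group.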